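Methyl for Methoxy: Forecasting Compound 4's Cytotoxicity

The compounds below may be only part of what the source reports. "The series", "measured", "known", "first", "only" and "open" are said of these compounds alone.

Measured so far:
compound 1, `Cc1cccc(Cn2cc(C(N)=O)c3c(N)ncnc32)c1`: > 100000 nM
compound 2, `Cn1cc(C(N)=O)c2c(N)ncnc21`: > 100000 nM
compound 3, `COc1ccc(Cn2cc(C(N)=O)c3c(N)ncnc32)cc1`: 47000 nM

Of the compounds shown here, three on a shared core have been tested in a functional assay on KB cells (Homo sapiens) for cytotoxicity; a lower number here means a stronger inhibitor, a higher number a weaker inhibitor. For compound 1 the value > 100000 nM is a limit of the assay, not a number. For compound 2 the value > 100000 nM is likewise a limit. For the measured compounds named here, compound 3 is the only one that yields a number, 47000 nM, so it is the sole readable point among the three. Going by the values given here, the single step between measured compounds that differ in one place, a step that the two limits leave unreadable from compound 1 to compound 2, cannot be sized because the limit of > 100000 nM in this assay, at which 2 of the 3 values shown sit, caps both of its ends.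

Compound 4, `Cc1ccc(Cn2cc(C(N)=O)c3c(N)ncnc32)cc1`, differs from compound 3 in one place: methyl in place of methoxy on an aromatic carbon. Among the compounds with values here, no measured step touches this change, and the only step on record gives no size at all. Nothing in the data therefore argues for a shift beyond the scatter in this assay in either direction. Compound 4 is accordingly expected to land near compound 3, with an estimate of 55000 nM and a range from 20000 nM to 150000 nM. That estimate implies a step of a 1.2-fold higher number from compound 3 to compound 4 (0.07 log units; within the scatter), essentially flat. Compound 3 sits at 47000 nM, and compound 4 is expected to sit close to that value.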

Compound 4, half-maximal inhibitory concentration: > 100000 nM
Compound 4 was reported as a limit; the forecaster's own chance of this, stated with the estimate: 35%; middle value at least 1.8-fold (0.25 log units) away from the limit.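

For the compounds shown here, until now no step in this assay could be sized, so the earlier compounds said nothing about the aromatic carbon para to a large group; methyl in place of methoxy at that place now gives the first readable step, an at least 2.1-fold higher number from compound 3 to compound 4 (0.32 log units; beyond the scatter). Compound 4 gives > 100000 nM, which is a limit of the assay and not a number, so the step has a lower bound only and the measurable value seen with methoxy does not survive this exchange. The steps to compound 4 from compound 2 and from compound 1 cannot be read, because all of their ends sit at one limit: the limit of > 100000 nM in this assay, at which 3 of the 4 values shown sit.

On these data alone, how far compound 4 lies past its limit remains open, and so does the full size of the step from methoxy to methyl. Also open, as far as these compounds go, is whether an ethoxy group, a hydroxyl group, a chlorine atom or an amine on the same aromatic carbon would give a readable value, as methoxy does, or fall to the limit, as methyl does.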